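The compounds below may be only part of what the source reports. "The series", "measured", "known", "first", "only" and "open" are said of these compounds alone.

Measured compounds in the series:
- compound 1 `C[C@H](Oc1ccc(S(C)(=O)=O)cc1C(=O)N1Cc2ccc(C(F)(F)F)cc2C1)C(F)(F)F`: 21 nM
- compound 2 `C[C@H](Oc1ccc(S(C)(=O)=O)cc1C(=O)N1Cc2ccc(N3CCN(C)CC3)cc2C1)C(F)(F)F`: 2080 nM
- compound 3 `C[C@H](Oc1ccc(S(C)(=O)=O)cc1C(=O)N1Cc2ccc(-c3ccncc3)cc2C1)C(F)(F)F`: 17 nM

In an assay on CHO cells for inhibition of sodium- and chloride-dependent glycine transporter 1 (Homo sapiens), read by scintillation counting (on this read-out lower numbers stand for an effect already at smaller amounts and higher numbers for an effect only at larger amounts of compound), compound 1 gives 21 nM and stands second highest of the three numbers, with compound 3 nearest: a 1.2-fold lower number from compound 1 to compound 3 (0.09 log units; within the scatter). Compound 2 is furthest away: a 99-fold higher number from compound 1 to compound 2 (2.00 log units; beyond the scatter). Compound 4 `C[C@H](Oc1ccc(S(C)(=O)=O)cc1C(=O)N1Cc2ccc(C3CCOCC3)cc2C1)C(F)(F)F` is not yet measured; it differs from compound 1 by oxan-4-yl in place of trifluoromethyl on an aromatic carbon.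

Among the compounds with values here, two measured steps bear on this change, both at the same aromatic carbon. The aromatic replacement in a 1.2-fold lower number from compound 1 to compound 3 (0.09 log units; within the scatter) left the number where it was, whereas the replacement in a 99-fold higher number from compound 1 to compound 2 (2.00 log units; beyond the scatter), which also brings in a ring that is not aromatic, cost a large step. Oxan-4-yl shares the non-aromatic ring with the group of compound 2 but carries no net charge and only one hydrogen-bond acceptor, so a loss smaller than that of compound 2 is expected, yet a step beyond the scatter is likely. For compound 4 the expected step is a 3.3-fold higher number from compound 1 to compound 4 (0.52 log units; beyond the scatter), giving an estimate of 70 nM with a range of 18 nM to 300 nM.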

Compound 4, half-maximal effective concentration: 14 nM
Beside the measured number, compound 4's estimate is 5.0-fold (0.70 log units) above it; the measured number lies below the stated range.
By their numbers in this assay, from the lowest: compounds 4, 3 and 1 (each within the scatter of the next); then compound 2.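

Oxan-4-yl is accepted at this aromatic carbon in this assay (a 1.5-fold lower number from compound 1 to compound 4 (0.18 log units; within the scatter)) and matches the aromatic pyridin-4-yl group (a 1.2-fold lower number from compound 3 to compound 4 (0.08 log units; within the scatter)), so a six-membered non-aromatic ring at this place does not by itself bring a large loss. The large gap stays with the 4-methylpiperazin-1-yl group alone (a 150-fold lower number from compound 2 to compound 4 (2.17 log units; beyond the scatter)), making compound 2 the only one of the four that stands apart, although it too carries a non-aromatic ring. Nothing available accounts for the gap between these two non-aromatic groups.

Open, as far as these compounds go, is which part of 4-methylpiperazin-1-yl goes with the loss, a question that 1-methylpiperidin-4-yl, piperazin-1-yl and morpholin-4-yl would separate. Also open, from the compounds shown here alone, is how a carboxylic acid or a longer chain at this aromatic carbon would read out.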